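Replacing 3-methylphenyl with furan-2-yl in compound 3

The source may hold more compounds than are shown below. What is called first, only, known or untested is meant among the compounds shown, and "the series" means these compounds.

In a functional assay on NCI-H460 cells (Homo sapiens) for antiproliferative activity, read by MTT assay, with a stated time of 48 h (a higher number here means a weaker inhibitor, a lower number a stronger inhibitor), compound 1 `COc1cc(-c2cccc3nc(-c4cccc(Br)c4)oc23)cc(OC)c1OC` gives 3800 nM as a measured number. Compound 2 `COc1cc(-c2cccc3nc(-c4ccc(Br)cc4)oc23)cc(OC)c1OC` shows > 25000 nM as a limit of the assay. Compound 3 `COc1cc(-c2cccc3nc(-c4cccc(C)c4)oc23)cc(OC)c1OC` also stands only at a limit of > 25000 nM and has no number. Compound 4 `COc1cc(-c2cccc3nc(-c4ccco4)oc23)cc(OC)c1OC` carries furan-2-yl in place of 3-methylphenyl on an aromatic carbon. The measured steps that bear on this change alter the same aryl group. Since an at least 6.5-fold higher number from compound 1 to compound 2 (0.81 log units; beyond the scatter) and an at least 6.5-fold higher number from compound 1 to compound 3 (0.81 log units; beyond the scatter) both end at a limit and neither tests furan-2-yl, only a modest move to a lower number is expected in this assay for compound 4, if any can be read. The expected step is an at least 1.6-fold lower number from compound 3 to compound 4 (0.22 log units; that floor lies within the scatter) on this estimate. For compound 4 the estimated value is 15000 nM with an expected range from 3000 nM to 40000 nM overall.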

Compound 4, half-maximal inhibitory concentration: 2600 nM
For compound 4 the middle estimate is 5.8-fold (0.76 log units) above the measured one; the whole stated range lies above it.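

In this assay, furan-2-yl gives an aryl-free-of-bromo compound a measured number at this position, with an at least 9.6-fold lower number from compound 3 to compound 4 (0.98 log units; beyond the scatter) and an at least 9.6-fold lower number from compound 2 to compound 4 (0.98 log units; beyond the scatter). Against the only other measured compound, there is a 1.5-fold lower number from compound 1 to compound 4 (0.16 log units; within the scatter), so furan-2-yl and 3-bromophenyl cannot be told apart here. The first two steps are floors, not sizes: the limit of > 25000 nM in this assay, at which 2 of the 4 values shown sit. From the compounds shown here alone, what an amine or a carboxylic acid would give on this carbon remains open. So does whether thiophen-2-yl or furan-3-yl would match furan-2-yl.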